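The compounds below may be only part of what the source reports. "The series", "measured", "known", "first", "only" and "open" are said of these compounds alone.

Measured so far:
- compound 1 `CCCOC(=O)c1c(NC(=O)N2CCN(C)CC2)sc2c1CCC2`: in an assay on cells for agonist activity at Toll-like receptor 2 (Homo sapiens), with a stated time of 24 h (on this read-out lower numbers stand for an effect already at smaller amounts and higher numbers for an effect only at larger amounts of compound), compound 1 gives 14200 nM
- compound 2 `CC(C)OC(=O)c1c(NC(=O)N2CCN(C)CC2)sc2c1CCC2`: in this assay compound 2 gives 4590 nM

Compound 2 stands at the lowest of the two numbers in this assay. For the measured compounds named here, its only neighbour is compound 1, and the single step in hand, a 3.1-fold lower number from compound 1 to compound 2 (0.49 log units; beyond the scatter), lies entirely on the ester: isopropyl in place of propyl on an oxygen next to a carbonyl group. Nothing else in the series has been varied.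

Compound 3 `CCN1CCN(C(=O)Nc2sc3c(c2C(=O)OC(C)C)CCC3)CC1` is the next compound to be measured in this assay. It differs from compound 2 by methyl in place of hydrogen on a saturated chain carbon bound to an amine nitrogen in a ring; read one bond further out, this is methyl to ethyl, that is 4-methylpiperazin-1-yl to 4-ethylpiperazin-1-yl. Going by the values given here, no measured step bears on this part of the molecule. The ester step from compound 1 to compound 2 does not touch the piperazine and gives no guide to how lengthening its alkyl group will read in this assay. Among the compounds with values here, with no precedent either way, the expectation for compound 3 is a step within the scatter, a 1.0-fold higher number from compound 2 to compound 3 (0.00 log units; within the scatter), with the uncertainty widened because the change is untested. Compound 3 is therefore estimated at 4600 nM, in the range 1500 nM to 14000 nM.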

Compound 3, half-maximal effective concentration: "not active" (no number reported)
For compound 3 the study gives words and no number; the estimate stays without a comparison.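

For the compounds shown here, compound 3 is reported in words only, without a number, so no step from compound 2 to compound 3 can be read in this assay. No measured evidence bears on this result. The compounds shown leave open how far 4-ethylpiperazin-1-yl in place of 4-methylpiperazin-1-yl shifts the read-out, and in which direction.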